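The source may report more compounds than this note shows. Statements on the series, on what has been measured and on what is new or still open speak of the compounds shown alone.

Three compounds share one core. Compound 1 `Nc1cc(N)c2nc(-c3ccccc3)c(Oc3ccc(Cl)c(Cl)c3)nc2c1` carries a dichlorophenyl ether on that core, compound 3 `CCOC(=O)[C@H](CCC(=O)O)NC(=O)c1ccc(Oc2nc3cc(N)cc(N)c3nc2-c2ccccc2)cc1` a larger ether that ends in an ester-bearing acid chain, and compound 2 `Nc1cc(N)c2nc(-c3ccccc3)c(NCc3ccc(Cl)c(Cl)c3)nc2c1` a dichlorobenzylamine. In a functional assay on M14 cells (Homo sapiens) for inhibition, read by sulforhodamine B assay, with a stated time of 48 h (on this read-out lower numbers stand for higher toxicity in this test and higher numbers for lower toxicity in this test), compound 1 reaches only the limit < 100000 nM, which is a boundary of the test and not a number. Compound 3 likewise gives only the limit < 100000 nM in this assay. Going by the values given here, compound 2 is the one that yields a number, 75900 nM, so it stands alone as the single measured value, the other two resting at the limit of < 100000 nM in this assay, at which 2 of the 3 values shown sit.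

Compound 4 `Nc1cc(N)c2nc(-c3ccccc3)c(NCc3ccc(F)cc3)nc2c1` differs from compound 2 in one place: 4-fluorophenyl in place of 3,4-dichlorophenyl on a saturated chain carbon bound to a nitrogen on an aromatic ring. Among the compounds with values here, no measured pair brackets this change, so the data give no direct guide to the size of the step. Since compound 2 already lies close to the limit, the step from compound 2 to compound 4 is expected to be modest, a 1.3-fold higher number from compound 2 to compound 4 (0.10 log units; within the scatter), toward weaker cell killing and possibly not beyond the usual scatter, with a fair chance that only a limit is reported. Compound 4 is therefore expected to show about 95000 nM, in the range 40000 nM to 200000 nM.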

Compound 4, concentration lethal to 50% of the cells: < 100000 nM
Compound 4: only a limit was reported; the forecaster's own chance of this, stated with the estimate: 50%; the middle value lies beyond the limit too.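

In this assay compound 4 gives < 100000 nM, which is a limit and not a number. Neither the step from compound 2 to compound 4 nor the step from compound 1 to compound 4 can be read: the limit of < 100000 nM in this assay, at which 3 of the 4 values shown sit.

The compounds shown leave open whether 4-fluorophenyl in place of 3,4-dichlorophenyl changes toxicity in this test at all, and by how much.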